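The compounds below may be only part of what the source reports. "The series", "measured", "known", "first", "only" and "open" are said of these compounds alone.

Three compounds share one core. Compound 1 `Nc1nccn2cc(-c3ccccc3)nc12` carries only hydrogen at the position of interest, compound 2 `Nc1nc(Br)cn2cc(-c3ccccc3)nc12` carries bromo there, and compound 3 `Nc1nc(-c2ccccc2)cn2cc(-c3ccccc3)nc12` carries a phenyl. In an assay on cells for displacement of a labelled ligand from transmembrane domain-containing protein TMIGD3 (Homo sapiens), read by scintillation counting, with a stated time of 120 min, tested at 1 uM (a lower number here means less inhibition, a higher number more inhibition at the concentration tested (going by the name of the read-out)), compound 1 gives 12%, compound 2 gives 14% and compound 3 gives 23%. The steps between them are small: a number 2 percentage points higher from compound 1 to compound 2 (within the scatter) and a number 9 percentage points higher from compound 2 to compound 3 (within the scatter) both fall within the scatter, while a number 11 percentage points higher from compound 1 to compound 3 (beyond the scatter) is the only difference that exceeds it. Compound 3 therefore holds the highest of the three numbers, but its gap to compound 2 lies within the scatter, so only its separation from compound 1 can be taken as real.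

Compound 4 `COc1cccc(-c2cn3cc(-c4ccccc4)nc3c(N)n2)c1` keeps the phenyl of compound 3 and adds to it: methoxy in place of hydrogen on an aromatic carbon. Among the compounds with values here, no measured step probes a substituent on that phenyl; the only related evidence is the modest gain from hydrogen to phenyl, a number 11 percentage points higher from compound 1 to compound 3 (beyond the scatter), and the within-scatter move a number 9 percentage points higher from compound 2 to compound 3 (within the scatter). A methoxy is a small addition compared with those changes, so the expected step of a number 4 percentage points higher from compound 3 to compound 4 (within the scatter) in this assay is estimated to stay within the scatter, with no clear direction. Compound 4 is accordingly expected to give about 27%, somewhere between 12% and 44%.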

Compound 4, a percentage reported as inhibition, at one concentration (the size of the read-out at that concentration, not a potency): 21%
Compound 4: middle estimate off by 6 percentage points, on the high side; measured number inside the range.
By their numbers in this assay, from the lowest: compounds 1, 2, 4 and 3 (each within the scatter of the next, the first and the last beyond it).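

In this assay, within the data shown here, methoxy on the phenyl gives a number 2 percentage points lower from compound 3 to compound 4 (within the scatter) and so produces no readable change: at this place on the ring, the first substituent leaves the number where the plain phenyl had it. Set against the earlier compounds, 3-methoxyphenyl in place of hydrogen gives a number 9 percentage points higher from compound 1 to compound 4 (within the scatter) and 3-methoxyphenyl in place of bromo gives a number 7 percentage points higher from compound 2 to compound 4 (within the scatter) and thus neither step can be told from noise, whereas a number 11 percentage points higher from compound 1 to compound 3 (beyond the scatter) was the one step that stood clear of the scatter, so compound 4 does not repeat that separation, even though compound 3 and compound 4 cannot be told apart. Nothing available here explains this outcome.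

As far as these compounds go, whether a different group on this phenyl, such as an amine or a carboxylic acid, or a longer chain in place of the methoxy, would move the number beyond the scatter remains open. From the compounds shown here alone, a percentage at a single concentration is also not a potency, so how these compounds would rank on a full concentration curve stays unknown.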